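This account rests on a few compounds, and the source may have more. Where it says the series, first, only, none or still open, it means among the compounds named here.

Among the measured compounds shown here, compound 1 `OC(Cc1ccccc1)c1cccc2[nH]ncc12` gives 7900 nM in an assay for binding affinity to Indoleamine 2,3-dioxygenase 1 (Homo sapiens), read by spectrophotometry, with a stated time of 30 min (on this read-out higher numbers stand for weaker binding and lower numbers for tighter binding), the highest of the three numbers so far; compound 3 `C#Cc1cc(C(O)Cc2ccccc2)c2cn[nH]c2c1` stands nearest at 1300 nM and compound 2 `OC(Cc1ccccc1)c1cc(Br)cc2[nH]ncc12` furthest at 140 nM. Compound 4 `OC(Cc1ccccc1)c1cc(-c2ccccc2)cc2[nH]ncc12` is not yet measured. It differs from compound 1 by phenyl in place of hydrogen on an aromatic carbon, the same place at which the two measured changes were made. Both measured steps therefore bear on it: a 56-fold lower number from compound 1 to compound 2 (1.75 log units; beyond the scatter) and a 6.1-fold lower number from compound 1 to compound 3 (0.78 log units; beyond the scatter). For the measured compounds named here, the step of a 9.3-fold higher number from compound 2 to compound 3 (0.97 log units; beyond the scatter) shows that the size of the gain at this carbon varies with the group entering, and no measured compound carries an aromatic ring there, so the size for phenyl is uncertain. For compound 4 a lowering beyond the scatter is expected, of a size between the two measured steps, as the expected step of a 13-fold lower number from compound 1 to compound 4 (1.12 log units; beyond the scatter). Compound 4 is accordingly estimated at 600 nM in this assay, with a range from 100 nM to 3500 nM.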

Compound 4, dissociation constant: 53000 nM
Compound 4: middle estimate off by 88-fold (1.95 log units), on the low side; measured number above the stated range.
By their numbers in this assay, from the lowest: compound 2; then compound 3; then compound 1; then compound 4.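

At this aromatic carbon, a substituent does not in itself lower the number: in this assay, phenyl gives a 6.7-fold higher number from compound 1 to compound 4 (0.83 log units; beyond the scatter), a change in the opposite direction to those seen with bromo and ethynyl. The choice of entering group is therefore decisive, with a 41-fold higher number from compound 3 to compound 4 (1.61 log units; beyond the scatter) and a 380-fold higher number from compound 2 to compound 4 (2.58 log units; beyond the scatter) when phenyl replaces those two groups. No measurement shown accounts for this reversal.

Going by these compounds, it remains open whether the rise follows from the aromatic ring itself or from the size of the entering group, which a pyridine ring, a cyclohexyl group or a longer alkyl chain at this carbon would help separate. On these data alone, the effect of small groups such as chloro, methyl or an amine at this carbon also remains open, as does whether any of them matches bromo.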